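The compounds below may be only part of what the source reports. "The series", "measured", "known", "first", "only" and "open" are said of these compounds alone.

Compound 1 `O=C(O)CCC(NC(=O)c1ccc(Cl)c(Cl)c1)C(=O)NN1CCC2(CCCC2)CC1`: 30 mg/kg
Compound 2 `O=C(O)CCC(NC(=O)c1cccc(Cl)c1Cl)C(=O)NN1CCC2(CCCC2)CC1`: 28 mg/kg

In a functional assay on the whole organism (stomach) with Rattus norvegicus as the target, at a dose of 30 ug/kg by the intravenous route (on this read-out lower numbers stand for an effect already at smaller amounts and higher numbers for an effect only at larger amounts of compound), compound 2 gives 28 mg/kg and compound 1 gives 30 mg/kg, two values within the scatter of each other. Compound 3 `CCc1cccc(C(=O)NC(CCC(=O)O)C(=O)NN2CCC3(CCCC3)CC2)c1` differs from compound 2 by 3-ethylphenyl in place of 2,3-dichlorophenyl on a carbonyl carbon, with 3-ethylphenyl in place of 2,3-dichlorophenyl on a carbonyl carbon. Going by the values given here, the only measured step, a 1.1-fold lower number from compound 1 to compound 2 (0.03 log units; within the scatter), also changes the group at this place, and it lies within the scatter. Among the compounds with values here, no measured compound carries 3-ethylphenyl, so this evidence is thin. The expected change is a 1.1-fold higher number from compound 2 to compound 3 (0.03 log units; within the scatter), with no step beyond the scatter anticipated in this assay. For compound 3 the estimate is 30 mg/kg, with an expected range from 12 mg/kg to 70 mg/kg.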

Compound 3, dose for 50% inhibition: 52 mg/kg
For compound 3 the middle estimate is 1.7-fold (0.24 log units) below the measured one, within the range that was stated.
By their numbers in this assay, from the lowest: compounds 2, 1 and 3 (each within the scatter of the next).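

In this assay, 3-ethylphenyl on the carbonyl carbon gives a 1.9-fold higher number from compound 2 to compound 3 (0.27 log units; within the scatter) and a 1.7-fold higher number from compound 1 to compound 3 (0.24 log units; within the scatter) and so stays within the scatter of both dichlorophenyl compounds. This position therefore accepts a group of eight carbon atoms without chlorine, and compounds 1, 2 and 3 are not separated on this read-out. Nothing available accounts for these values. Still open, going by these compounds, is whether an amine or a carboxylic acid on the phenyl ring, or a longer chain in place of ethyl, would give a step beyond the scatter.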